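Swapping the benzyl ether for a pyridylmethyl ether

The source may report more compounds than this note shows. Statements on the series, on what has been measured and on what is new or still open speak of the compounds shown alone.

Compound 3 `Cc1c(C2CC2)nc2ccc(-n3ccc(OCc4ccc(C(C)C)cc4)cc3=O)cn12` sits at the higher of the two numbers read in an assay on CHO cells for displacement of a labelled ligand from melanin-concentrating hormone receptor 1 (Rattus norvegicus), read by scintillation counting, with a stated time of 1 h (on this read-out lower numbers stand for stronger inhibition and higher numbers for weaker inhibition), giving 240 nM. Its nearest neighbour is compound 2 `Cc1c(C2CC2)nc2ccc(-n3ccc(OCc4ccccc4)cc3=O)cn12`, which in this assay gives 28 nM. Compound 1 `Cc1oc2ccc(NC(=O)COc3ccc(OC(F)(F)F)cc3)cc2c1C` belongs to a different series and reaches only a limit in this assay, > 1000 nM, as noted by the limit of > 1000 nM in this assay, at which 1 of the 3 values shown sits. Going by the values given here, the step of an 8.6-fold higher number from compound 2 to compound 3 (0.93 log units; beyond the scatter) is the only measured change in the ether part and is the one that bears on what follows.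

Compound 4 `Cc1c(C2CC2)nc2ccc(-n3ccc(OCc4ccccn4)cc3=O)cn12` differs from compound 3 by pyridin-2-yl in place of 4-isopropylphenyl on a saturated chain carbon bound to an oxygen on an aromatic ring. Part of that change undoes the isopropyl, which on its own was worth an 8.6-fold higher number from compound 2 to compound 3 (0.93 log units; beyond the scatter); the rest, phenyl to pyridyl, has no measured counterpart among these compounds. Compound 4 is therefore expected to land closer to compound 2 than to compound 3, a step of about a 4.8-fold lower number from compound 3 to compound 4 (0.68 log units; beyond the scatter). The estimate for compound 4 in this assay is 50 nM, with a likely range from 15 nM to 200 nM.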

Compound 4, half-maximal inhibitory concentration: 150 nM
Estimate against measurement, compound 4: 3.0-fold (0.48 log units) below; measured number inside the range.
By their numbers in this assay, from the lowest: compound 2; then compounds 4 and 3 (each within the scatter of the next). At a limit, above all of these: compound 1.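

In this assay, a nitrogen in the ring is enough on its own to move the number at this position: pyridin-2-yl in place of phenyl, with no added carbon group, gives (a 5.4-fold higher number from compound 2 to compound 4 (0.73 log units; beyond the scatter)). The unsubstituted benzyl ether of compound 2 therefore remains apart from both changed ethers, which shows that the position responds to more than the isopropyl group. The two changed ethers cannot be told apart, since 4-isopropylbenzyl and (pyridin-2-yl)methyl stay within the scatter (a 1.6-fold lower number from compound 3 to compound 4 (0.20 log units; within the scatter)), even though one group is larger and the other carries a hydrogen-bond acceptor.

Going by these compounds, it remains open whether pyridin-3-yl or pyridin-4-yl would read like pyridin-2-yl, and whether a methoxy group or a fluorine on the phenyl ring would read like isopropyl. Nothing measured here accounts for either shift.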